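The source may report more compounds than this note shows. Statements on the series, on what has been measured and on what is new or still open speak of the compounds shown alone.

Measured compounds:
- compound 1 `COc1ccc(CNC(=O)CSc2nc3ccc(NC(=O)c4ccc([N+](=O)[O-])cc4)cc3s2)cc1` — > 100000 nM in a functional assay on HepG2 cells (Homo sapiens) for cytotoxicity, read by MTT assay, with a stated time of 48 h; on this read-out lower numbers stand for stronger inhibition and higher numbers for weaker inhibition
- compound 2 `CNC(=O)CSc1nc2ccc(NC(=O)c3ccc(Cl)cc3)cc2s1` — 15300 nM

The read-out for compound 1 is a limit of the assay and not a number; it sits at the limit of > 100000 nM in this assay, at which 1 of the 2 values shown sits. Within the data shown here, compound 2 is therefore the only compound here with an actual number in this assay, and its value stands alone, with nothing to compare it against except that limit.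

The step of interest leads from compound 2 to compound 3 `CNC(=O)CSc1nc2ccc(NC(=O)c3ccc([N+](=O)[O-])cc3)cc2s1`, which has not yet been measured. The change is nitro in place of chloro on an aromatic carbon. The rest of the molecule, including the shared core and the small amide on the other end, is unchanged.

Among the measured compounds shown here, no measured pair differs in exactly this one place, so the size of the step can only be guessed. The expectation is a modest weakening, a 2.0-fold higher number from compound 2 to compound 3 (0.29 log units; within the scatter), with real uncertainty about whether the assay will return a number at all. Compound 3 is estimated at 30000 nM, within a range from 8000 nM to 100000 nM.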

Compound 3, half-maximal inhibitory concentration: > 100000 nM
Compound 3 gave a limit, no number (the forecaster's own chance of this, stated with the estimate: 35%); at least 3.3-fold (0.52 log units) between middle value and limit.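

In this assay, the group at this spot on the outer aromatic ring clearly matters: with 4-nitrophenyl in place of 4-chlorophenyl and the rest of the molecule unchanged, the data show an at least 6.5-fold higher number from compound 2 to compound 3 (0.81 log units; beyond the scatter). This size is only a lower bound, as compound 3 gives a limit of the assay and not a number, so the true gap cannot be stated. Compound 1 also carries the nitro group, but the step between compound 1 and compound 3 cannot be read, and the two nitro compounds now share one reading: the limit of > 100000 nM in this assay, at which 2 of the 3 values shown sit.

The compounds shown leave open how other groups at this position would behave, for example whether an amine, a methoxy group or a plain hydrogen would give a number close to that of compound 2 or reach the limit as well. As far as these compounds go, it also remains unknown what the 4-methoxyphenyl group of compound 1 would do in a compound carrying the chloro group, where a measured number could make its step readable.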